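Fluoro in Place of Methyl on Compound 2

The source may hold more compounds than are shown below. What is called first, only, known or untested is meant among the compounds shown, and "the series" means these compounds.

Compound 1 `CC#CC(CC(=O)O)c1ccc(OCc2ccn3cc(-c4ccc(C)cc4)nc3c2)cc1` gives 618 nM in an assay on isolated protein for agonist activity at Free fatty acid receptor 1 (Homo sapiens); a higher number here means that more compound is needed for the effect, a lower number that less compound is needed.
Compound 2 `CC#CC(CC(=O)O)c1ccc(OCc2ccn3cc(-c4ccccc4C)nc3c2)cc1` gives 459 nM in this assay.

Among the measured compounds shown here, compound 2 and compound 1 sit within the scatter of each other, as the only measured step shows: a 1.3-fold lower number from compound 1 to compound 2 (0.13 log units; within the scatter). Compound 3 `CC#CC(CC(=O)O)c1ccc(OCc2ccn3cc(-c4ccccc4F)nc3c2)cc1` differs from compound 2 by fluoro in place of methyl on an aromatic carbon. For the measured compounds named here, no measured step swaps methyl for fluoro, so that step offers no direct guide, and a step within the scatter is expected: a 1.1-fold higher number from compound 2 to compound 3 (0.04 log units; within the scatter). Compound 3 is therefore estimated at 500 nM, in a range from 200 nM to 1250 nM in this assay.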

Compound 3, half-maximal effective concentration: 705 nM
For compound 3 the middle estimate is 1.4-fold (0.15 log units) below the measured one, within the range that was stated.
By their numbers in this assay, from the lowest: compounds 2, 1 and 3 (each within the scatter of the next).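

At this aromatic carbon, ortho to a large group, fluoro and methyl cannot be told apart in this assay, with a 1.5-fold higher number from compound 2 to compound 3 (0.19 log units; within the scatter). Replacing 4-methylphenyl with 2-fluorophenyl also stays within the scatter, with a 1.1-fold higher number from compound 1 to compound 3 (0.06 log units; within the scatter), so these three aryl groups give no clear separation here. No supporting measurement offers an explanation for this result.

Still open, going by these compounds, is how a larger or different group at this position, such as an amine, a carboxylic acid or a longer chain, would read in this assay.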